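The source may hold more compounds than are shown below. What is called first, only, known or untested is meant among the compounds shown, and "the series" means these compounds.

Measured compounds:
- Compound 1, `CCOC(=O)c1csc(NC(=O)[C@H](CCCCNS(N)(=O)=O)NC(=O)OCc2ccccc2)n1`, in an assay for inhibition of protein deacetylase HDAC6 (Homo sapiens) (a lower number here means a stronger inhibitor, a higher number a weaker inhibitor), gives 580 nM.
- Compound 2, `COc1ccc(-c2csc(NC(=O)[C@H](CCCCNS(N)(=O)=O)NC(=O)OCc3ccccc3)n2)cc1`, gives 200 nM.
- Compound 3, `NS(=O)(=O)NCCCC[C@H](NC(=O)OCc1cccc(Cl)c1)C(=O)Nc1nc(-c2ccccc2)cs1`, gives 280 nM.

All three share the same core, a lysine-like chain ending in a sulfamide, linked through an amide to a thiazole. Compound 3 stands second highest of the three numbers; its nearest neighbour is compound 2, within the scatter of repeated measurements, while its gap to compound 1 is beyond the scatter.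

Compound 4, `NS(=O)(=O)NCCCC[C@H](NC(=O)Nc1ccccc1)C(=O)Nc1nc(-c2ccccc2)cs1`, differs from compound 3 in one place: anilino in place of (3-chlorobenzyl)oxy on a carbonyl carbon. The carbamate of compound 3 thus becomes a urea in compound 4.

Within the data shown here, the only measured step, a 2.9-fold lower number from compound 1 to compound 2 (0.46 log units; beyond the scatter), concerns the thiazole end of the molecule, not the position changed here, so it says nothing direct about this change. The carbamate-to-urea exchange has no measured precedent among these compounds. A step within or just beyond the scatter is therefore expected, with a slight lean towards a higher number, giving a 1.4-fold higher number from compound 3 to compound 4 (0.15 log units; within the scatter). Compound 4 is estimated at 400 nM, with a range from 150 nM to 1200 nM.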

Compound 4, half-maximal inhibitory concentration: 560 nM
The estimate for compound 4 lay 1.4-fold (0.15 log units) below the measured number, within the range that was stated.
By their numbers in this assay, from the lowest: compounds 2, 3, 4 and 1 (each within the scatter of the next, the first and the last beyond it).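

In this assay, putting anilino in place of (3-chlorobenzyl)oxy on this carbonyl carbon gives a 2.0-fold higher number from compound 3 to compound 4 (0.30 log units; within the scatter). Among these compounds, this is the first measured change at this position, and it turns a carbamate into a urea without moving the number further than repeat measurements can. Several things change at once, since the linking oxygen gives way to a nitrogen, the chlorine is lost, and a hydrogen-bond acceptor is replaced by a hydrogen-bond donor, yet together they leave a result that cannot be told apart from that of the carbamate. Nothing available accounts for this result or ties it to any one of those changes.

Among the compounds shown here, the single step also cannot show which of those parts matters, if any does, and groups such as 3-chloroanilino or benzylamino on the same carbonyl carbon would help to pull them apart. On these data alone, how a simple amine or a longer chain ending in a phenyl group would behave at this position also remains open, as does whether the result holds with the 4-methoxyphenyl group of compound 2 on the other end of the molecule.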